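This account rests on a few compounds, and the source may have more. Where it says the series, first, only, none or still open, it means among the compounds named here.

Measured in a functional assay on HCT-116 cells (Homo sapiens) for cytotoxicity, read by MTT assay, with a stated time of 72 h (on this read-out lower numbers stand for stronger inhibition and higher numbers for weaker inhibition), each entry a limit of the assay and not a number:
- compound 1 `C[C@@H](Nc1c(C(=O)NCc2ccc(F)cc2)nc(Br)c2cccnc12)c1ccccc1`: > 20000 nM
- compound 2 `NCCCNc1c(C(=O)NCc2ccc(F)cc2)nc(Br)c2cccnc12`: > 20000 nM
- compound 3 `CN(C)CCCNc1c(C(=O)NCc2ccc(F)cc2)nc(Br)c2cccnc12`: > 10000 nM

Compound 3 stands only at a limit, > 10000 nM. The series gives no measured number to work from: the limit of > 10000 nM in this assay, at which 1 of the 3 values shown sits, and (the limit of > 20000 nM in this assay, at which 2 of the 3 values shown sit).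

The next structure is compound 4 `NCCNc1c(C(=O)NCc2ccc(F)cc2)nc(Br)c2cccnc12`, and the change is amino in place of (dimethylamino)methyl on a saturated chain carbon, two bonds along the chain from a nitrogen on an aromatic ring.

The steps bearing on it are a step that the two limits leave unreadable from compound 2 to compound 3 and a step that the two limits leave unreadable from compound 1 to compound 2, and neither has a readable size. Compound 2, which also ends in amino, still gives a limit, > 20000 nM.

No step beyond the scatter is therefore expected in this assay, and the estimated step is a step that the limit leaves unreadable from compound 3 to compound 4.

Compound 4 is expected at 20000 nM, with an estimated range of 8000 nM to 50000 nM, most likely reported as a limit again.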

Compound 4, half-maximal inhibitory concentration: > 20000 nM
Compound 4: a limit, no number; the forecaster's own chance of this, stated with the estimate: 85%; the middle value lies on the limit itself.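

Within the data shown here, compound 4, like compound 1, compound 2 and compound 3, gives only a limit in this assay, and no step among them can be read. The compounds shown leave open whether any amine side chain on the shared core reaches a measured number.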